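Solubility stays low when the far ring gains a group

This account rests on a few compounds, and the source may have more. Where it says the series, first, only, none or still open, it means among the compounds named here.

Measured so far in a physicochemical assay for solubility, using the shake flask method, in simulated intestinal fluid, measured as kinetic solubility, with a stated time of 2 h, at 25 degrees C, at pH 6.5; on this read-out lower numbers stand for lower solubility and higher numbers for higher solubility:
Compound 1 `Cc1nc(C(=O)O)c(N)c2c1C(=O)N(Cc1ccccc1)C2=O` gives 177000 nM as a number
Compound 2 `Cc1nc(C(N)=O)c(N)c2c1C(=O)N(Cc1ccccc1)C2=O` gives < 5000 nM as a limit
Compound 3 `Cc1noc(-c2nc(C)c3c(c2N)C(=O)N(Cc2ccccc2)C3=O)n1` gives < 5000 nM as a limit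

Compound 3 stands at the limit of < 5000 nM in this assay, at which 2 of the 3 values shown sit, and this is a limit, not a number. Compound 4 `Cc1noc(-c2nc(C)c3c(c2N)C(=O)N(Cc2ccc(OC(F)(F)F)cc2)C3=O)n1` keeps everything in compound 3 except for one change, with trifluoromethoxy in place of hydrogen on an aromatic carbon of a six-membered aromatic ring of carbon only, para to a large group trifluoromethoxy in place of hydrogen on an aromatic carbon in all.

Two measured steps are large, namely an at least 35-fold lower number from compound 1 to compound 2 (1.54 log units; beyond the scatter) and an at least 35-fold lower number from compound 1 to compound 3 (1.54 log units; beyond the scatter) and both replace the carboxy group of compound 1. Neither sets a size for the new change, which leaves that part of compound 3 untouched. The remaining measured step is a step that the two limits leave unreadable from compound 2 to compound 3 and it offers no size at all. Among the compounds with values here, no measured step alters the ring that receives trifluoromethoxy, so no step beyond the scatter is expected in this assay and a reading at the same limit is the likeliest outcome. The estimated step is a step that the limit leaves unreadable from compound 3 to compound 4 and it should be read as an expectation only. For compound 4 the estimate is 3000 nM with an expected range from 500 nM to 5000 nM in this read-out.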

Compound 4, solubility: < 5000 nM
Compound 4: no number, only a limit; the forecaster's own chance of this, stated with the estimate: 90%; the middle value does not contradict the limit.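

In this assay compound 4 gives < 5000 nM, which is a limit and not a number. Compound 3 also sits at a limit, so the step from compound 3 to compound 4 cannot be read. The compounds shown leave open whether trifluoromethoxy in place of hydrogen changes the solubility at all.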